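The source may hold more compounds than are shown below. What is called first, only, known or untested is meant among the compounds shown, and "the series" means these compounds.

Compound 3 `Cc1c(OC[C@@H](C)COc2ccc(C(=O)O)cc2Cl)ccc(C(=O)CC(C)(C)C)c1O` gives 1650 nM in an assay for positive allosteric modulation of metabotropic glutamate receptor 3 (Rattus norvegicus) (on this read-out higher numbers stand for an effect only at larger amounts of compound and lower numbers for an effect already at smaller amounts), the lowest of the two numbers that this set contains. Compound 1 `Cc1c(OC[C@@H](C)COc2cc(C(=O)O)ccc2F)ccc(C(=O)CC(C)(C)C)c1O` gives 3950 nM in this assay. For compound 2 `Cc1ccc(OC[C@H](C)COc2ccc(C(=O)CC(C)(C)C)c(O)c2C)cc1C(=O)O`, this assay reports only a limit, > 10000 nM. Every measured step exchanges one aryl group for another on an oxygen on a saturated carbon: a 2.4-fold lower number from compound 1 to compound 3 (0.38 log units; beyond the scatter), an at least 6.0-fold lower number from compound 2 to compound 3 (0.78 log units; beyond the scatter) and an at least 2.5-fold higher number from compound 1 to compound 2 (0.40 log units; beyond the scatter). Compound 4 `Cc1c(OC[C@@H](C)COc2ccc3c(c2)C(=O)NC3)ccc(C(=O)CC(C)(C)C)c1O` differs from compound 3 in the same place: a group of 10 heavy atoms (8 carbon, 1 nitrogen, 1 oxygen; one five-membered non-aromatic ring with 1 hetero atom, one six-membered aromatic ring of carbon only) in place of a group of 10 heavy atoms (7 carbon, 2 oxygen, 1 chlorine; one six-membered aromatic ring of carbon only), on an oxygen on a saturated carbon. In each measured step both groups kept a carboxy substituent on their six-membered aromatic ring, whereas in compound 4 that carboxy group leaves and a group with a five-membered non-aromatic ring with 1 hetero atom enters. Within the data shown here, no measured step follows a change of this kind, so the expectation can rest only on how far the three exchanges of the aryl group moved the number in this assay, from modest to at least modest. Compound 4 is therefore expected to show a step of a 1.8-fold higher number from compound 3 to compound 4 (0.26 log units; within the scatter) in this assay, with the direction uncertain and a wide spread allowed. The estimate for compound 4 in this assay is 3000 nM, expected to lie between 700 nM and 10000 nM.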

Compound 4, half-maximal effective concentration: "not active" (no number reported)
Compound 4: no number reported, so the estimate cannot be set against anything.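

Among these compounds, compound 4 is recorded as "not active" in this assay, with no number reported, and no step from compound 3 to compound 4 can be read. The compounds shown leave open where compound 4 would fall relative to the limit reported for compound 2: the limit of > 10000 nM in this assay, at which 1 of the 4 values shown sits.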